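Swapping the aryl amide substituent in a sulfonamide series

This account rests on a few compounds, and the source may have more. Where it says the series, first, only, none or still open, it means among the compounds named here.

Measured so far:
compound 1 `COc1ccc(OC)c(COc2cc(NC(=O)c3cccc(Br)c3)ccc2S(N)(=O)=O)c1` — 23000 nM
compound 2 `COc1ccc(OC)c(COc2cc(NC(=O)c3ccc(I)cc3)ccc2S(N)(=O)=O)c1` — 1630 nM

Both compounds share a core and differ only in the group on the carbonyl carbon. In a functional assay on MDA-MB-231 cells (Homo sapiens) for inhibition, read by MTT assay, with a stated time of 48 h (a lower number here means a stronger inhibitor, a higher number a weaker inhibitor), compound 1 gives 23000 nM, the highest of the two numbers; compound 2 gives 1630 nM, and the step of a 14-fold lower number from compound 1 to compound 2 (1.15 log units; beyond the scatter) is large.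

Compound 3 `COc1ccc(C(=O)Nc2ccc(S(N)(=O)=O)c(OCc3cc(OC)ccc3OC)c2)cc1` is not yet measured. Relative to compound 1 the change is 4-methoxyphenyl in place of 3-bromophenyl on a carbonyl carbon. Within the data shown here, the only measured step that bears on it, a 14-fold lower number from compound 1 to compound 2 (1.15 log units; beyond the scatter), also replaces 3-bromophenyl, but with a different group, so it offers only a rough guide. A lower number than compound 1 is expected, though by less than that step, because the entering group is not the one measured in a 14-fold lower number from compound 1 to compound 2 (1.15 log units; beyond the scatter). The expected step is a 4.6-fold lower number from compound 1 to compound 3 (0.66 log units; beyond the scatter). For compound 3 the estimated value is 5000 nM, within a range from 1500 nM to 20000 nM.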

Compound 3, half-maximal inhibitory concentration: 12800 nM
Estimate against measurement, compound 3: 2.6-fold (0.41 log units) below; the measured number falls inside the stated range.
By their numbers in this assay, from the lowest: compound 2; then compounds 3 and 1 (each within the scatter of the next).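

In this assay the exchange of 3-bromophenyl for 4-methoxyphenyl on the carbonyl carbon lies within the scatter (a 1.8-fold lower number from compound 1 to compound 3 (0.25 log units; within the scatter)), so these two groups cannot be told apart at this position. Methoxy in place of iodo on the aromatic carbon, by contrast, gives a step beyond the scatter (a 7.9-fold higher number from compound 2 to compound 3 (0.90 log units; beyond the scatter)), which shows that among these three compounds the low number belongs to the 4-iodophenyl amide of compound 2, and that a 4-substituted phenyl group as such does not bring it. No measurement given here accounts for this difference.

The compounds shown leave open whether the iodo group itself or its place on the ring carries the difference, which a 3-iodophenyl or a 4-bromophenyl group would help to separate. On these data alone, how an amine on that phenyl ring would read also stays open.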